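The compounds below may be only part of what the source reports. "The series", "measured", "known", "first", "only" and "open" are said of these compounds alone.

Measured so far in a physicochemical assay for lipophilicity; on this read-out higher numbers stand for higher lipophilicity and lower numbers for lower lipophilicity:
- compound 1 `C[C@H]1O[C@@H](n2cnc3c(N)nc(OC4CCOC4)nc32)[C@H](O)[C@@H]1O` gives -0.06
- compound 2 `C[C@H]1O[C@@H](n2cnc3c(N)nc(OC4CC(F)(F)C4(F)F)nc32)[C@H](O)[C@@H]1O` gives 1.3

Of these two numbers, compound 1 holds the lower, so it is the starting point at the low end of the series. Compound 3 `C[C@H]1O[C@@H](n2cnc3c(N)nc(OCC4CCC(F)(F)CC4)nc32)[C@H](O)[C@@H]1O` has not yet been measured. It carries (4,4-difluorocyclohexyl)methyl in place of oxolan-3-yl on an oxygen on an aromatic ring, and the counted difference is (4,4-difluorocyclohexyl)methyl in place of oxolan-3-yl on an oxygen on an aromatic ring.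

Within the data shown here, only one measured step bears on this change. With 2,2,3,3-tetrafluorocyclobutyl in place of oxolan-3-yl at the same place, the read-out moved by a number 1.36 log units higher from compound 1 to compound 2 (beyond the scatter), a large step beyond the scatter. Among the measured compounds shown here, no measured compound carries the (4,4-difluorocyclohexyl)methyl group, so this single step is a loose guide. An upward step of similar size is therefore expected in this assay, with the estimated step being a number 1.66 log units higher from compound 1 to compound 3 (beyond the scatter).

For compound 3 the expected value is 1.6, with an estimated range from 1 to 2.2.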

Compound 3, distribution coefficient: 1.7
Beside the measured number, compound 3's estimate is 0.10 log units below it; measured number inside the range.
By their numbers in this assay, from the lowest: compound 1; then compound 2; then compound 3.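

In this assay, this place on an oxygen on an aromatic ring now shows a second large change: with (4,4-difluorocyclohexyl)methyl in place of oxolan-3-yl the read-out moves by a number 1.76 log units higher from compound 1 to compound 3 (beyond the scatter) and so rises beyond the scatter with both replacements tested. The two replacements are not interchangeable, since (4,4-difluorocyclohexyl)methyl in place of 2,2,3,3-tetrafluorocyclobutyl gives a number 0.40 log units higher from compound 2 to compound 3 (beyond the scatter) in this assay, a modest step in which the group with difluoro in its name stands higher than the group with tetrafluoro in its name, so across these compounds the read-out does not follow the fluorine count. Nothing measured here explains either step, and oxolan-3-yl and (4,4-difluorocyclohexyl)methyl differ at once in ring size, heavy-atom count and hydrogen-bond acceptors, so these differences cannot be told apart.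

Going by these compounds, it stays open where a plain cyclohexylmethyl group would fall at this place, which would set the two fluorine atoms apart from the carbon ring and its methylene link. On these data alone, it also stays open whether an amine or a carboxylic acid on the same ring would bring the read-out back towards that of compound 1.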